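A Butylamino Exchange at the Assay Limit

The compounds below may be only part of what the source reports. "The series", "measured", "known", "first", "only" and "open" are said of these compounds alone.

In an ADME assay on HeLa cells (Homo sapiens) for cytotoxicity, read by resazurin assay, with a stated time of 65 h (a lower number here means that less compound is needed, a higher number that more compound is needed for the effect), compound 1 (`CCCCc1cc(C(=O)OCC)c(NC(=O)c2ccc([N+](=O)[O-])o2)s1`) gives > 20000 nM, a limit and not a number. Compound 2 (`CCc1cc(C(=O)OC)c(NC(=O)c2ccc([N+](=O)[O-])o2)s1`) gives > 20000 nM, again a limit. As far as these compounds go, compound 3 (`CCCCOC(=O)c1cc(CC)sc1NC(=O)c1ccc([N+](=O)[O-])o1`) gives > 20000 nM, also only a limit, so its true position is unknown. All the measurements share this ceiling: the limit of > 20000 nM in this assay, at which 3 of the 3 values shown sit. Among the compounds with values here, the one measured step, a step that the two limits leave unreadable from compound 2 to compound 3, therefore has no readable size. Compound 4 (`CCCCNC(=O)c1cc(CC)sc1NC(=O)c1ccc([N+](=O)[O-])o1`) carries butylamino in place of butoxy on a carbonyl carbon. Within the data shown here, no measured step tests this exchange, so this assay offers no basis for expecting a change beyond the scatter. The expected step is a number no higher from compound 3 to compound 4 (the limit leaves the size open). For compound 4, the estimate is 20000 nM, with an expected range of 8000 nM to 40000 nM.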

Compound 4, half-maximal effective concentration: > 20000 nM
Compound 4 was reported as a limit; the forecaster's own chance of this, stated with the estimate: 70%; the middle value lies on the limit itself.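

In this assay no step to compound 4 from compound 2 or compound 3 can be read: the limit of > 20000 nM in this assay, at which 4 of the 4 values shown sit.

The compounds shown leave open whether butylamino in place of butoxy on a carbonyl carbon changes the true read-out at all.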